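The compounds below may be only part of what the source reports. "The series", "measured", "known", "first", "only" and "open" are said of these compounds alone.

Measured compounds:
compound 1, `Cc1ccc(S(=O)(=O)c2cnc3c(F)cccc3c2-c2cccc(F)c2)cc1F`: 3.92 mL/min
compound 2, `Cc1ccc(S(=O)(=O)c2cnc3c(F)cccc3c2-c2ccc(F)cc2)cc1F`: 2.75 mL/min
compound 3, `COc1ccc(-c2c(S(=O)(=O)c3ccc(C)c(F)c3)cnc3c(F)cccc23)cc1`: 3.27 mL/min

In an ADME assay on microsomes from liver (Homo sapiens) for metabolic stability, tested at 2.5 uM (on this read-out lower numbers stand for slow clearance and higher numbers for fast clearance), compound 2 carries the lowest of the three numbers, but the steps of a 1.4-fold lower number from compound 1 to compound 2 (0.15 log units; within the scatter) and a 1.2-fold higher number from compound 2 to compound 3 (0.08 log units; within the scatter) both fall within the scatter, so the three compounds cannot really be told apart on this read-out. Compound 4, `O=S(=O)(c1cccc(F)c1)c1cnc2c(F)cccc2c1-c1ccc(F)cc1`, differs from compound 2 in one place: hydrogen in place of methyl on an aromatic carbon.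

The measured steps all concern the other aromatic ring attached to the shared core: a 1.4-fold lower number from compound 1 to compound 2 (0.15 log units; within the scatter), a 1.2-fold lower number from compound 1 to compound 3 (0.08 log units; within the scatter) and a 1.2-fold higher number from compound 2 to compound 3 (0.08 log units; within the scatter), each within the scatter. Within the data shown here, none of them alters the ring that changes here, so no measured step bears directly on the removal of the methyl group. With nothing in the data pointing to a shift in either direction, the expectation for compound 4 is a step of a 1.0-fold higher number from compound 2 to compound 4 (0.01 log units; within the scatter), that is, no change beyond the scatter. Compound 4 is therefore estimated at 2.8 mL/min, with a range from 1.4 mL/min to 5.6 mL/min.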

Compound 4, intrinsic clearance in a liver preparation (reported as CLH), per the amount of preparation that the assay uses: 0.19 mL/min
The estimate for compound 4 lay 15-fold (1.17 log units) above the measured number, and the stated range ends above it.
By their numbers in this assay, from the lowest: compound 4; then compounds 2, 3 and 1 (each within the scatter of the next).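

Replacing 3-fluoro-4-methylphenyl with 3-fluorophenyl gives a 14-fold lower number from compound 2 to compound 4 (1.16 log units; beyond the scatter) in this assay, the only step among these compounds that lies beyond the scatter. This shows that the position on the aromatic carbon ortho to a fluoro group strongly affects the read-out, and that the loss of one methyl group, a single heavy atom, is enough to move compound 4 towards slow clearance, whereas the changes on the other aromatic ring in compound 1, compound 2 and compound 3 stayed within the scatter. Nothing measured here explains the size of this step.

Going by these compounds, only methyl and hydrogen appear at this position, so how an ethyl group, a chlorine atom or a hydroxymethyl group would read there stays open. Also open, on these data alone, is whether removing the methyl group gives a similar step with the 3-fluorophenyl of compound 1 or the 4-methoxyphenyl of compound 3 on the other ring.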